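A few compounds are considered here, and "the series" means these few. Any claim that something is new, unique, unknown or untested is made for them only; others in the source may bear on it.

Three compounds of this series carry a measured number. Compound 1 `N#Cc1cc(C(NC(=O)c2ccc3cnccc3c2)C2CCNCC2)ccc1Cl` gives 80 nM in an assay on isolated protein for inhibition of RAC-alpha serine/threonine-protein kinase (Homo sapiens); a higher number here means a weaker inhibitor, a lower number a stronger inhibitor. Compound 2 `O=C(NC(c1cnc(Cl)c(Cl)c1)C1CCNCC1)c1ccc2cnccc2c1` gives 140 nM in this assay, and the change of a 1.8-fold higher number from compound 1 to compound 2 (0.24 log units; within the scatter) stays within the scatter. Compound 3 `O=C(NC(c1ccc(Cl)c(Cl)c1)C1CCNCC1)c1ccc2cnc(F)cc2c1` gives 20 nM in this assay and stands lowest of the three, with its distances to compound 1 and to compound 2 both beyond the scatter, so it is the strongest inhibitor among the measured compounds.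

Compound 4 `O=C(NC(c1ccc(Cl)c(Cl)c1)C1CCNCC1)c1ccc2cnc(Cl)cc2c1` has not yet been measured in this assay. It differs from compound 3 by chloro in place of fluoro on an aromatic carbon. Going by the values given here, only one measured step exists in this set, the step from compound 1 to compound 2, and it concerns the group on the saturated chain carbon, not the position on the fused ring where the fluoro sits in compound 3. Among the compounds with values here, no measured step therefore bears directly on the change from compound 3 to compound 4, and no evidence in the set points to a shift beyond the scatter in either direction. The estimated step of a 1.1-fold higher number from compound 3 to compound 4 (0.04 log units; within the scatter) is accordingly expected to be small. Compound 4 is expected to give about 22 nM in this assay, with a range from 8 nM to 60 nM.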

Compound 4, half-maximal inhibitory concentration: 140 nM
The estimate for compound 4 lay 6.4-fold (0.80 log units) below the measured number; measured number outside the range, above it.
By their numbers in this assay, from the lowest: compound 3; then compounds 1, 2 and 4 (each within the scatter of the next).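

The aromatic carbon next to the ring nitrogen proves sensitive in this assay: exchanging fluoro for chloro, a change of one heavy atom for one heavy atom with no change in hydrogen-bond donors, acceptors or net charge, gives a 7.0-fold higher number from compound 3 to compound 4 (0.85 log units; beyond the scatter). Going by these compounds alone, the earlier compounds could not show this, since their only step concerned the group on the saturated chain carbon and stayed within the scatter, whereas this is the first step between compounds differing in one place that lies beyond it. The compounds shown offer nothing that accounts for the higher number with chloro at this position.

As far as these compounds go, with only fluoro and chloro compared here, it remains open how an amine, a methoxy group or a plain hydrogen on this carbon would stand in this assay against compound 3 and compound 4, so no trend across substituents can yet be drawn. From the compounds shown here alone, it also remains open whether the same exchange would give a step of similar size with the 4-chloro-3-cyanophenyl or 5,6-dichloropyridin-3-yl group on the saturated chain carbon in place of the group shared by compound 3 and compound 4.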